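The compounds below may be only part of what the source reports. "The series", "measured", "known", "first", "only" and "open" are said of these compounds alone.

Measured in a functional assay on Raji cells (Homo sapiens) for antiproliferative activity, read by CCK-8 assay, with a stated time of 72 h, tested at 40 uM; a higher number here means more inhibition at the concentration tested (going by the name of the read-out), a lower number less inhibition:
compound 1 `CCOC(=O)c1sc(-c2cccc(NC(=O)c3ccc(C(F)(F)F)cc3)c2)nc1Nc1ccc(N2CCN(C)CC2)cc1`, 33%
compound 2 `CCOC(=O)c1sc(-c2cccc(NC(=O)c3cccc(F)c3)c2)nc1Nc1ccc(N2CCN(C)CC2)cc1`, 82.8%

Going by the values given here, compound 2 stands highest of the two numbers; its nearest neighbour is compound 1, and the single step of a number 49.8 percentage points higher from compound 1 to compound 2 (beyond the scatter) is large. Compound 3 `CCOC(=O)c1sc(-c2cccc(NC(=O)c3ccccc3F)c2)nc1Nc1ccc(N2CCN(C)CC2)cc1` keeps the same atoms, joined differently: 2-fluorophenyl in place of 3-fluorophenyl on a carbonyl carbon. Among the compounds with values here, no measured step moves the fluorine within the ring, so the only step on hand does not bear directly on this change. The expected step of a number 12.8 percentage points lower from compound 2 to compound 3 (beyond the scatter) in this assay is therefore set near zero, with a wide band. Compound 3 is estimated at 70%, between 40% and 92%.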

Compound 3, a percentage reported as inhibition, at one concentration (the size of the read-out at that concentration, not a potency): 89.8%
Compound 3: the middle estimate sits 19.8 percentage points below what was measured, and the stated range covers the measured number.
By their numbers in this assay, from the lowest: compound 1; then compounds 2 and 3 (each within the scatter of the next).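

In this assay, 2-fluorophenyl in place of 3-fluorophenyl on the carbonyl carbon gives a number 7 percentage points higher from compound 2 to compound 3 (within the scatter), so the two fluorophenyl groups are not told apart at this concentration. The large gap to the 4-(trifluoromethyl)phenyl compound holds for the second fluorophenyl group too, with a number 56.8 percentage points higher from compound 1 to compound 3 (beyond the scatter). Nothing available explains these results.

Going by these compounds, what an unsubstituted phenyl or a 2-methoxyphenyl group would give on the same carbonyl carbon remains open. Also open, on these data alone, is whether the large step follows from the trifluoromethyl group itself or from its place on the ring.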